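From Trifluorophenyl to Cyclohexyl: Expected Cytotoxicity

This account rests on a few compounds, and the source may have more. Where it says the series, first, only, none or still open, it means among the compounds named here.

Compound 3 `Cc1ccc(S(=O)(=O)/N=C(/CCNC2=CC(=O)c3ccccc3C2=O)Nc2cc(F)c(F)c(F)c2)cc1` stands second highest of three compounds in an ADME assay on HEK293 cells (Homo sapiens) for cytotoxicity, read by MTT assay, with a stated time of 48 h (a higher number here means a weaker inhibitor, a lower number a stronger inhibitor), giving 82600 nM. Compound 2 `COc1ccc(N/C(CCNC2=CC(=O)c3ccccc3C2=O)=N\S(=O)(=O)c2ccc(C)cc2)c(OC)c1` gives 83000 nM, a gap of a 1.0-fold lower number from compound 2 to compound 3 (0.00 log units; within the scatter), while compound 1 `COc1ccc(N/C(CCNC2=CC(=O)c3ccccc3C2=O)=N\S(=O)(=O)c2ccc(C)cc2)cc1` gives 35100 nM, with a 2.4-fold higher number from compound 1 to compound 3 (0.37 log units; beyond the scatter) and a 2.4-fold higher number from compound 1 to compound 2 (0.37 log units; beyond the scatter) both modest shifts. Compound 4 `Cc1ccc(S(=O)(=O)/N=C(/CCNC2=CC(=O)c3ccccc3C2=O)NC2CCCCC2)cc1` differs from compound 3 by cyclohexyl in place of 3,4,5-trifluorophenyl on an amine nitrogen. For the measured compounds named here, none of the measured steps exchanges an aromatic ring for a saturated one; they only vary the groups on the ring attached to the amine nitrogen, and none moved the number far, so no basis exists for expecting a large shift. The step from compound 3 to compound 4 is expected to be a 1.4-fold lower number from compound 3 to compound 4 (0.14 log units; within the scatter), within the scatter. Compound 4 is therefore estimated at 60000 nM, between 25000 nM and 150000 nM.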

Compound 4, half-maximal inhibitory concentration: 50100 nM
Estimate against measurement, compound 4: 1.2-fold (0.08 log units) above, and the stated range covers the measured number.
By their numbers in this assay, from the lowest: compounds 1, 4, 3 and 2 (each within the scatter of the next, the first and the last beyond it).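

At this amine nitrogen, an aromatic ring is not needed to keep the number in this range: in this assay, the saturated cyclohexyl stays within the scatter of all three aryl compounds, with a 1.6-fold lower number from compound 3 to compound 4 (0.22 log units; within the scatter) and a 1.7-fold lower number from compound 2 to compound 4 (0.22 log units; within the scatter) and also a 1.4-fold higher number from compound 1 to compound 4 (0.15 log units; within the scatter) as the steps. Compound 4 thus sits close to both compound 1 and compound 2, although those two lie beyond the scatter of each other. Nothing available explains why these numbers stay so close.

On these data alone, whether a smaller ring such as cyclopropyl or an open butyl chain would behave like cyclohexyl remains open. So does the effect of an amine or a carboxylic acid on the ring.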